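This account rests on a few compounds, and the source may have more. Where it says the series, first, only, none or still open, it means among the compounds named here.

Compound 2 `CCC1(Cc2ccccc2)OS(=O)(=O)C=C1OCc1ccc(Cl)cc1` was tested in an ADME assay on HEL cells (Homo sapiens) for cytotoxicity, with a stated time of 3 days; a lower number here means that less compound is tolerated, a higher number that more compound is tolerated. Its value there is only a limit of the assay, > 200000 nM. The related compound 1 `CCC1(Cc2ccccc2)OS(=O)(=O)C=C1OCc1ccccc1` gives 200000 nM in this assay. Compound 3 `CCC1(Cc2ccccc2)OS(=O)(=O)C=C1OC(=O)c1ccccc1` also reaches only a limit, > 200000 nM. The measured steps are therefore not readable in size: a number no lower from compound 1 to compound 2 (the limit leaves the size open), a number no lower from compound 1 to compound 3 (the limit leaves the size open) and a step that the two limits leave unreadable from compound 2 to compound 3, because of the limit of > 200000 nM in this assay, at which 2 of the 3 values shown sit. The next compound 4 `CCC1(Cc2ccccc2)OS(=O)(=O)C=C1OCCCCc1ccccc1` differs from compound 2 as follows: 3-phenylpropyl in place of 4-chlorophenyl on a saturated chain carbon bound to an oxygen on an unsaturated carbon. Going by the values given here, no measured step touches this kind of chain, so no shift beyond the usual scatter is expected, and the step from compound 2 to compound 4 is estimated at a number no higher from compound 2 to compound 4 (the limit leaves the size open). Compound 4 is expected to give about 200000 nM in this assay, between 100000 nM and 400000 nM.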

Compound 4, half-maximal cytotoxic concentration: 99000 nM
For compound 4 the middle estimate is 2.0-fold (0.31 log units) above the measured one; measured number below the stated range.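

In this assay, going by these compounds alone, 3-phenylpropyl in place of phenyl on this saturated chain carbon gives a 2.0-fold lower number from compound 1 to compound 4 (0.31 log units; beyond the scatter), the first step whose size can be read. With 3-phenylpropyl in place of 4-chlorophenyl, the result is an at least 2.0-fold lower number from compound 2 to compound 4 (0.30 log units; that floor lies within the scatter). The earlier steps cannot be read, because they rest on a limit of the assay: the limit of > 200000 nM in this assay, at which 2 of the 4 values shown sit.

From the compounds shown here alone, whether a longer chain, or a chain ending in an amine or a carboxylic acid, would shift the number further stays open. So does whether a chloro on the ring of compound 4 would change its value.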